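Lengthening the Amine Side Chain: A Modest Expectation

The source may hold more compounds than are shown below. What is called first, only, known or untested is meant among the compounds shown, and "the series" means these compounds.

Of the compounds shown here, three built on one shared core have been tested in a functional assay on HCT-15 cells (Homo sapiens) for inhibition, read by MTT assay, with a stated time of 72 h; a higher number here means a weaker inhibitor, a lower number a stronger inhibitor. Compound 1 `COc1cc(Oc2cccc(Nc3ccccc3)c2)cc(OC)c1CNCc1ccccc1` gives 5020 nM. Compound 2 `COc1cc(Oc2cccc(Nc3ccccc3)c2)cc(OC)c1CNCc1ccc(C)cc1`, which carries a methyl in place of hydrogen on an aromatic carbon of the benzyl group, gives 5400 nM, and compound 3 `COc1cc(Oc2cccc(Nc3ccccc3)c2)cc(OC)c1CNCc1ccc(Cl)cc1`, with chloro in place of hydrogen on an aromatic carbon, gives 4850 nM. Compound 1 therefore holds the second highest of the three numbers, yet all three sit within the scatter of one another: a 1.1-fold higher number from compound 1 to compound 2 (0.03 log units; within the scatter), a 1.0-fold lower number from compound 1 to compound 3 (0.01 log units; within the scatter) and a 1.1-fold lower number from compound 2 to compound 3 (0.05 log units; within the scatter).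

Compound 4 `COc1ccc(CCCNCc2c(OC)cc(Oc3cccc(Nc4ccccc4)c3)cc2OC)cc1` differs from compound 1 in a single place: 2-(4-methoxyphenyl)ethyl in place of phenyl on a saturated chain carbon bound to an amine nitrogen. Within the data shown here, none of the measured steps touches the chain itself; each only swaps a small group on the aromatic ring, and each stayed within the scatter. They give no direct guide to a longer chain, but they do show that this region of the molecule has so far tolerated change without any shift beyond the scatter in this assay. A step of a 1.0-fold lower number from compound 1 to compound 4 (0.00 log units; within the scatter) is therefore expected. Compound 4 is estimated at 5000 nM, with a likely range from 2200 nM to 11000 nM.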

Compound 4, half-maximal inhibitory concentration: 730 nM
Beside the measured number, compound 4's estimate is 6.8-fold (0.84 log units) above it, and the stated range ends above it.
By their numbers in this assay, from the lowest: compound 4; then compounds 3, 1 and 2 (each within the scatter of the next).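

Small swaps on the benzyl ring left the number in this assay unchanged within the scatter, but replacing benzyl with 3-(4-methoxyphenyl)propyl on the amine gives a 6.9-fold lower number from compound 1 to compound 4 (0.84 log units; beyond the scatter). The same change gives a 6.6-fold lower number from compound 3 to compound 4 (0.82 log units; beyond the scatter) and a 7.4-fold lower number from compound 2 to compound 4 (0.87 log units; beyond the scatter), so this position does respond to a larger change, and compound 4 is the strongest inhibitor of the four. No measurement shown here accounts for this gain.

This single change both lengthens the chain and adds a methoxy group, so the compounds shown cannot separate the two contributions. On these data alone, whether plain 3-phenylpropyl or 4-methoxybenzyl would match compound 4 remains open, as does the outcome for a still longer chain such as 4-(4-methoxyphenyl)butyl.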